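A few compounds are considered here, and "the series" means these few. Any claim that something is new, unique, unknown or untested is made for them only; others in the source may bear on it.

For the measured compounds named here, in a functional assay on PC-3 cells (Homo sapiens) for inhibition, read by sulforhodamine B assay (a higher number here means a weaker inhibitor of growth, a lower number a stronger inhibitor of growth), compound 1 (`Cc1ccc2[nH]c(-c3ccc(-c4ccc(-c5cccc(Cl)c5)cc4)cc3)nc2c1`) gives 2670 nM and holds the middle of the three numbers so far. Compound 3 (`Clc1cccc(-c2ccc(-c3ccc(-c4nc5ccccc5[nH]4)cc3)cc2)c1`) gives 33700 nM on the high side, and compound 2 (`COc1cc(-c2ccc(-c3ccc(-c4nc5cc(C)ccc5[nH]4)cc3)cc2)cc(OC)c1OC`) gives 180 nM on the low side.

Compound 4 (`Cc1ccc2[nH]c(-c3ccc(-c4ccc(-c5ccc(O)cc5)cc4)cc3)nc2c1`) carries 4-hydroxyphenyl in place of 3-chlorophenyl on an aromatic carbon, with the rest of compound 1 kept (4-hydroxyphenyl in place of 3-chlorophenyl on an aromatic carbon). Going by the values given here, the only measured step is a 13-fold higher number from compound 1 to compound 3 (1.10 log units; beyond the scatter) and lies beyond the scatter, but it concerns hydrogen in place of methyl. Compound 4 keeps that methyl, so this step gives no direct size for the new change.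

Among the compounds with values here, no measured step isolates the swap. Within the data shown here, the one loose guide is that compound 2 also keeps the methyl, has a different aryl group in that place and shows a lower number than compound 1.

A moderate move toward a lower number is therefore expected, and the estimated change is a 3.0-fold lower number from compound 1 to compound 4 (0.47 log units; beyond the scatter) with wide uncertainty. In this assay compound 4 is estimated at 900 nM with an expected range of 200 nM to 4000 nM for now.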

Compound 4, concentration for 50% growth inhibition: 30000 nM
For compound 4 the middle estimate is 33-fold (1.52 log units) below the measured one, and the stated range ends below it.
By their numbers in this assay, from the lowest: compound 2; then compound 1; then compounds 4 and 3 (each within the scatter of the next).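

Notes on the series: in this assay the aryl group on the shared core is not a tolerant place, since 4-hydroxyphenyl in place of 3-chlorophenyl gives an 11-fold higher number from compound 1 to compound 4 (1.05 log units; beyond the scatter). For the compounds shown here, the earlier step concerned only the methyl, so this is the first measured step showing that a change at this aryl position alone, with the methyl kept, can be large. Compound 2, which also keeps the methyl, gives 180 nM, so a change of aryl group here does not move the number in one direction only.

No measured evidence accompanies this result to account for the step. Still open, as far as these compounds go, is whether the loss of chlorine, the hydroxyl itself or the change of its place on the ring carries the step, and how a 4-aminophenyl or 4-carboxyphenyl group would read here.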